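A few compounds are considered here, and "the series" means these few. Any claim that something is new, unique, unknown or untested is made for them only; others in the source may bear on it.

In a functional assay on MOLT-4 cells (Homo sapiens) for cytotoxicity, read by CCK-8 assay, with a stated time of 24 h (on this read-out higher numbers stand for weaker inhibition and lower numbers for stronger inhibition), compound 1 (`C=CC(=O)N1C(=O)CC(c2ccc(C)cc2)Sc2ccccc21`) gives 87600 nM as its value. Compound 2 (`C=CC(=O)N1C(=O)CC(c2ccccc2Cl)Sc2ccccc21`) gives 80300 nM as its value, and compound 3 (`C=CC(=O)N1C(=O)CC(c2cccs2)Sc2ccccc21`) gives 557000 nM as its value. The place of the 2-chlorophenyl compound on these numbers is fixed by a 1.1-fold lower number from compound 1 to compound 2 (0.04 log units; within the scatter) and by a 6.9-fold higher number from compound 2 to compound 3 (0.84 log units; beyond the scatter) on the other side. Compound 4 (`C=CC(=O)N1C(=O)CC(c2ccccc2C(F)(F)F)Sc2ccccc21`) has not yet been measured. It carries trifluoromethyl in place of chloro on an aromatic carbon, ortho to a large group (trifluoromethyl in place of chloro on an aromatic carbon). Within the data shown here, no measured step covers this exact swap. The closest guide is a 1.1-fold lower number from compound 1 to compound 2 (0.04 log units; within the scatter) as a change that keeps the six-membered aromatic ring of carbon only. The larger 6.4-fold higher number from compound 1 to compound 3 (0.80 log units; beyond the scatter) and a 6.9-fold higher number from compound 2 to compound 3 (0.84 log units; beyond the scatter) both bring in thiophen-2-yl, and compound 4 makes no such change. The expected result is a 1.0-fold lower number from compound 2 to compound 4 (0.00 log units; within the scatter) and no step beyond the scatter is anticipated. In this assay compound 4 is expected at 80000 nM with an estimated range from 30000 nM to 210000 nM around that figure.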

Compound 4, half-maximal inhibitory concentration: 84400 nM
The estimate for compound 4 lay 1.1-fold (0.02 log units) below the measured number, and the stated range covers the measured number.
By their numbers in this assay, from the lowest: compounds 2, 4 and 1 (each within the scatter of the next); then compound 3.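

In this assay, trifluoromethyl in place of chloro on an aromatic carbon, ortho to a large group, gives a 1.1-fold higher number from compound 2 to compound 4 (0.02 log units; within the scatter) and so stays within the scatter. The earlier steps shown here exchanged the whole group on the saturated ring carbon, whereas this one keeps the six-membered aromatic ring of carbon only and shows that four heavy atoms can stand at this place instead of one without a step beyond the scatter. Nothing available explains why the read-out holds across this swap.

The compounds shown leave open whether an amine or a carboxylic acid on this same aromatic carbon would also stay within the scatter of compound 2. They also leave open whether an unsubstituted phenyl group would stand with compound 1, compound 2 and compound 4 or with compound 3.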